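The compounds below may be only part of what the source reports. "The series", "measured", "known", "first", "only" and "open" are said of these compounds alone.

Of the compounds shown here, three from one series have been measured in a functional assay on COLO 205 cells (Homo sapiens) for cytotoxicity, read by MTT assay, with a stated time of 24 h; a higher number here means a weaker inhibitor, a lower number a stronger inhibitor. Compound 1, `CC(C)(C)c1ccc(-c2nnc(SCCCN3CCN(c4ccccc4)CC3)[nH]2)cc1`, gives only a limit of the assay in this assay, > 300000 nM. Compound 2, `CC(C)(C)c1ccc(-c2nn(CCCN3CCN(c4cccc(Cl)c4)CC3)c(=S)[nH]2)cc1`, gives a limit as well in this assay, > 300000 nM. Compound 3, `Cc1ccc(-c2nn(CCCN3CCN(c4cccc(Cl)c4)CC3)c(=S)[nH]2)cc1`, likewise gives no more than a limit in this assay, > 300000 nM. Among the measured compounds shown here, the one step that changes a single place, a step that the two limits leave unreadable from compound 2 to compound 3, cannot be read in size; all three values sit at the limit of > 300000 nM in this assay, at which 3 of the 3 values shown sit. Compound 3 therefore stands at the limit, with no numbered value among the three to set it against.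

Compound 4, `S=c1[nH]c(-c2ccc(Cl)cc2)nn1CCCN1CCN(c2cccc(Cl)c2)CC1`, differs from compound 3 in one place: chloro in place of methyl on an aromatic carbon. For the measured compounds named here, no measured step bears directly on this exchange, and the only measured step, methyl in place of tert-butyl, is itself unreadable. The expectation for this assay thus rests on the three limits alone, which give no sign that a change at this position would bring the value into the readable range. Compound 4 is therefore expected to give a limit again, with an estimate of 300000 nM and a range from 60000 nM to 300000 nM. The step this estimate implies, a number no higher from compound 3 to compound 4 (the limit leaves the size open), is expected to be none beyond the scatter.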

Compound 4, half-maximal inhibitory concentration: > 300000 nM
Compound 4 ended at the assay's limit; the forecaster's own chance of this, stated with the estimate: 85%; the middle value sits exactly at the limit.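

Compound 4 also gives only a limit in this assay, > 300000 nM. Neither step into compound 4, from compound 2 or from compound 3, can be read in size: the limit of > 300000 nM in this assay, at which 4 of the 4 values shown sit. The compounds shown leave open whether tert-butyl, methyl and chloro at this place differ at all in this assay, since none has a readable value.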